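A Pentyl Chain in Place of Sec-Butyl

A few compounds are considered here, and "the series" means these few. Any claim that something is new, unique, unknown or untested is made for them only; others in the source may bear on it.

Two measured compounds set the scene. Compound 1 `CCC(C)/N=C(\C)c1c(O)c2ccccc2[nH]c1=O` was examined in an assay on isolated protein for inhibition of myosin-2 (Bos taurus), read by spectrophotometry, with a stated time of 24 min; a higher number here means a weaker inhibitor, a lower number a stronger inhibitor. In this assay compound 1 gives only a limit, >= 100000 nM, and no number. Compound 2 `C/C(=N\Cc1ccccc1)c1c(O)c2ccccc2n(C)c1=O` carries a different substituent on its double-bonded nitrogen and a methylated core. In this assay compound 2 also gives only a limit, >= 100000 nM. Both results sit at the limit of >= 100000 nM in this assay, at which 2 of the 2 values shown sit, so compound 1 stands at the edge of what this assay can report, with no measured number for either compound.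

The unmeasured compound 3 `CCCCC/N=C(\C)c1c(O)c2ccccc2[nH]c1=O` differs from compound 1 by pentyl in place of sec-butyl on a double-bonded nitrogen. Among the compounds with values here, no measured pair isolates this change, so its size can only be expected. Because compound 1 rests at the limit of >= 100000 nM in this assay, at which 2 of the 2 values shown sit, the step is expected to be a step that the limit leaves unreadable from compound 1 to compound 3, none beyond the usual scatter. Compound 3 is therefore estimated at 150000 nM, within a range from 50000 nM to 500000 nM, and is itself expected to be reported only as a limit.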

Compound 3, half-maximal inhibitory concentration: >= 100000 nM
Compound 3: only a limit was reported; the forecaster's own chance of this, stated with the estimate: 80%; the middle value lies beyond the limit too.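

Compound 3, like compound 1, is reported in this assay only as a limit and not as a number, so no step between compound 1 and compound 3 can be read: the limit of >= 100000 nM in this assay, at which 3 of the 3 values shown sit.

The compounds shown leave open how strongly any of them inhibits, and whether pentyl in place of sec-butyl on a double-bonded nitrogen changes that inhibition at all.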